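A Second Swap on the Saturated Chain

This account rests on a few compounds, and the source may have more. Where it says the series, first, only, none or still open, it means among the compounds named here.

In a functional assay on MCF7 cells (Homo sapiens) for cytotoxicity, read by MTT assay, with a stated time of 72 h (on this read-out higher numbers stand for weaker inhibition and lower numbers for stronger inhibition), compound 1 `CC(C)[S+]([O-])CCCCN=C=S` gives 8820 nM. Compound 2 `[O-][S+](CCCCN=C=S)Cc1cccs1` gives 4140 nM, and compound 3 `CC(C)[S+]([O-])CCCCCN=C=S` gives 6780 nM. Compound 3 stands in the middle of these three numbers, but within the usual scatter of each of the other two, so neither gap shows a real difference.

Compound 4 `CC(C)[S+]([O-])CCCCCCN=C=S` has not yet been measured. Its structure differs from that of compound 3 by a group of 4 heavy atoms (2 carbon, 1 nitrogen, 1 sulfur; no ring) in place of a group of 3 heavy atoms (1 carbon, 1 nitrogen, 1 sulfur; no ring), on a saturated chain carbon, five bonds along the chain from a sulfur. The same kind of change has been measured once, four bonds along the chain from a sulfur rather than five: a 1.3-fold lower number from compound 1 to compound 3 (0.11 log units; within the scatter). This single step is small and cannot establish a trend, so no change beyond the scatter is expected in this assay. The expected step is a 1.2-fold lower number from compound 3 to compound 4 (0.07 log units; within the scatter). Compound 4 is estimated at 5800 nM, with an expected range from 2900 nM to 11000 nM.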

Compound 4, half-maximal inhibitory concentration: 9760 nM
Estimate against measurement, compound 4: 1.7-fold (0.23 log units) below; low and high end bracket the measured number.
By their numbers in this assay, from the lowest: compounds 2, 3, 1 and 4 (each within the scatter of the next, the first and the last beyond it).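

In this assay, the change has now been read at a second place on the saturated chain, five bonds along the chain from a sulfur, and a 1.4-fold higher number from compound 3 to compound 4 (0.16 log units; within the scatter) shows no real difference there. Set beside a 1.3-fold lower number from compound 1 to compound 3 (0.11 log units; within the scatter), this gives two steps of the same kind, both within the scatter and printed in opposite directions, so compounds 1, 3 and 4 show no trend with this chain change. No measurement here offers an explanation for either small step.

The compounds shown leave open whether a longer chain would move the number beyond the scatter. They also leave open whether an amine in place of the entering group, on the same saturated chain carbon, would do so.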